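A few compounds are considered here, and "the series" means these few. Any claim that something is new, unique, unknown or untested is made for them only; others in the source may bear on it.

Compound 1 `COc1cc(NS(=O)(=O)c2ccc(C)cc2[N+](=O)[O-])c2ncccc2c1`. In an assay on HUVEC cells for inhibition of transcription factor p65 (Homo sapiens) (on this read-out higher numbers stand for larger maximal responses and lower numbers for smaller maximal responses), compound 1 reaches > 90%, which is a limit of the assay and not a number.
Compound 2 `COc1cc(NS(=O)(=O)c2ccc(C)cc2[N+](=O)[O-])c2nc(C)ccc2c1`. In this assay compound 2 reaches > 90%, again a limit of the assay.

Compound 2 thus stands at the top of what is shown: the limit of > 90% in this assay, at which 2 of the 2 values shown sit. Among the compounds with values here, the one measured step, a step that the two limits leave unreadable from compound 1 to compound 2, is therefore not readable in size, and it concerns a methyl in place of hydrogen on an aromatic carbon, a different kind of change from the one now in question.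

Compound 3 `COc1cc(NS(=O)(=O)c2ccc(C)cc2)c2nc(C)ccc2c1` differs from compound 2 by hydrogen in place of nitro on an aromatic carbon. Within the data shown here, no measured step bears on the loss of the nitro group, so there is no basis for reading a direction from the data; the response of compound 3 is simply not anchored by any measured pair. On that footing compound 3 is expected to give about 75% in this assay, within a range of 40% to 100%, meaning an estimated step of a number at least 15 percentage points lower from compound 2 to compound 3 (beyond the scatter).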

Compound 3, largest response reached (reported as efficacy), in percent of the reference or control that the assay uses: > 90%
Compound 3 gave a limit, no number; the forecaster's own chance of this, stated with the estimate: 30%; at least 15 percentage points between middle value and limit.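

Compound 2 and compound 3 both end at a limit of this assay, not at a number, so the step between them cannot be read: the limit of > 90% in this assay, at which 3 of the 3 values shown sit.
The compounds shown leave open whether losing the nitro group changes the response at all, and in which direction.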